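Swapping Isobutyl for Methoxyethyl on a Shared Core Tested Against KAT2B

This account rests on a few compounds, and the source may have more. Where it says the series, first, only, none or still open, it means among the compounds named here.

Compound 1: `CC(C)CNC(=O)Cn1sc2ccccc2c1=O` gives 95%
Compound 2: `Cc1ccc(-c2csc(-n3sc4ccccc4c3=O)n2)cc1` gives 70%
Compound 3: `CCCCc1ccc(-n2sc3ncc(-c4ccccc4)cc3c2=O)cc1` gives 54%

These three compounds were tested in an assay on isolated protein for inhibition of histone acetyltransferase KAT2B (Homo sapiens), read by fluorescence, with a stated time of 10 min, tested at 50 uM; on this read-out higher numbers stand for more inhibition at the one concentration tested (going by the name of the read-out) and lower numbers for less inhibition. Compound 1 stands highest of the three numbers. Its nearest neighbour is compound 2, whose value lies lower by a margin beyond the usual scatter, and compound 3 lies lower still, again beyond the scatter. No two of these compounds differ in only one place, so the shared core is the only common thread, and the numbers say nothing about which single change matters.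

Among the compounds with values here, compound 4, `COCCNC(=O)Cn1sc2ccccc2c1=O`, is the one untested compound, and it differs from compound 1 in a single spot: methoxymethyl in place of isopropyl on a saturated chain carbon bound to an amide-type nitrogen. The shared core and the amide linkage are untouched; only the end of the short chain on the amide nitrogen changes.

Within the data shown here, with no comparable step among the measured compounds, the expectation rests on compound 1 alone, whose value 95% in this assay sits close to the top of what the read-out can report. The expected step of a number 7 percentage points lower from compound 1 to compound 4 (within the scatter) is therefore small and downward, within the scatter. Compound 4 is estimated to give 88%, in a range from 70% to 98%.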

Compound 4, a percentage reported as inhibition, at one concentration (the size of the read-out at that concentration, not a potency): 92%
For compound 4 the middle estimate is 4 percentage points below the measured one; the measured number falls inside the stated range.
By their numbers in this assay, from the lowest: compound 3; then compound 2; then compounds 4 and 1 (each within the scatter of the next).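

In this assay, within the data shown here, the step of a number 3 percentage points lower from compound 1 to compound 4 (within the scatter) gives the first direct comparison in this set, where only the end of the chain changes: methoxymethyl in place of isopropyl on a saturated chain carbon bound to an amide-type nitrogen. The exchange brings in an oxygen and one hydrogen-bond acceptor, yet the two compounds cannot be told apart on this read-out, so at this position and this concentration, the isopropyl end is not needed for the high inhibition seen with compound 1. Nothing at hand explains this result, and the data give no cause for it.

As far as these compounds go, how an amine, a carboxylic acid or a longer chain at this spot would read remains open, since the two ends compared here have the same number of heavy atoms and neither contains a ring. Both numbers also come from a single concentration and sit near the top of what a percentage can report, so whether the two compounds would still match in potency at lower concentrations is an open question as well.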